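Methylcarbamoyl for phenyl: compound 3 to compound 4

The source may hold more compounds than are shown below. What is called first, only, known or untested is meant among the compounds shown, and "the series" means these compounds.

In a functional assay (mast cells) for inhibition, with Rattus norvegicus as the target (a higher number here means that more compound is needed for the effect, a lower number that less compound is needed), three compounds share one core and differ only in a single group on an aromatic carbon. Compound 1 `CC1CC/C(=N\Nc2ccc(F)cc2)c2ncc(C(=O)O)c(=O)n21` gives 1200 nM, compound 2 `CCOc1ccc(N/N=C2\CCC(C)n3c2ncc(C(=O)O)c3=O)cc1` gives 17600 nM and compound 3 `CC1CC/C(=N\Nc2ccc(-c3ccccc3)cc2)c2ncc(C(=O)O)c(=O)n21` gives 4400 nM. Compound 3 therefore stands in the middle of the three numbers.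

The next compound is compound 4 `CNC(=O)c1ccc(N/N=C2\CCC(C)n3c2ncc(C(=O)O)c3=O)cc1`, with methylcarbamoyl in place of phenyl on an aromatic carbon, para to a large group: methylcarbamoyl in place of phenyl on an aromatic carbon.

Among the measured compounds shown here, three measured steps bear on this place: a 3.7-fold higher number from compound 1 to compound 3 (0.56 log units; beyond the scatter), a 4.0-fold lower number from compound 2 to compound 3 (0.60 log units; beyond the scatter) and a 15-fold higher number from compound 1 to compound 2 (1.17 log units; beyond the scatter). All lie beyond the scatter, so the number responds to changes here, with modest to large steps. For the measured compounds named here, none of the measured compounds carries methylcarbamoyl, so the data give no direction for this change. The expected outcome is therefore no step beyond the scatter, though a modest or large step either way remains possible. The estimated step is a 1.1-fold higher number from compound 3 to compound 4 (0.06 log units; within the scatter). Compound 4 is expected at 5000 nM, with an estimated range of 1300 nM to 18000 nM.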

Compound 4, half-maximal effective concentration: 100000 nM
The estimate for compound 4 lay 20-fold (1.30 log units) below the measured number; the whole stated range lies below it.
By their numbers in this assay, from the lowest: compound 1; then compound 3; then compound 2; then compound 4.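

Methylcarbamoyl is the group that asks for the most compound at this position in this assay, with a 23-fold higher number from compound 3 to compound 4 (1.36 log units; beyond the scatter), a 5.7-fold higher number from compound 2 to compound 4 (0.75 log units; beyond the scatter) and an 83-fold higher number from compound 1 to compound 4 (1.92 log units; beyond the scatter), so the position spans a wider range than the first three compounds showed. Although methylcarbamoyl has fewer heavy atoms than phenyl, the number rises on this exchange, so heavy-atom count does not predict the direction of this step. The exchange also adds a hydrogen-bond donor and a hydrogen-bond acceptor and removes a ring, but no measurement shown separates these changes or explains the rise.

Going by these compounds, a carbamoyl group without the methyl and a dimethylcarbamoyl group at this position remain open, as does a methylsulfonyl group. Their numbers would show whether the rise follows the amide hydrogen, the carbonyl or neither.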